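The source may report more compounds than this note shows. Statements on the series, on what has been measured and on what is new or still open speak of the compounds shown alone.

Measured so far in a functional assay on HT-29 cells (Homo sapiens) for cytotoxicity, read by MTT assay, with a stated time of 72 h; on this read-out lower numbers stand for higher toxicity in this test and higher numbers for lower toxicity in this test:
- compound 1, `CS/C(=N\C(=O)c1cc2ccccc2s1)NC(=O)c1cc2ccccc2s1`, gives 88200 nM
- compound 2, `CS/C(=N\C(=O)c1ccco1)NC(=O)c1ccco1`, gives > 100000 nM
- compound 3, `O=C(/N=C(/NC(=O)c1ccco1)[Se]Cc1ccccc1)c1ccco1`, gives 89100 nM

The value of compound 2 in this assay is a limit of the assay and not a number, as the limit of > 100000 nM in this assay, at which 1 of the 3 values shown sits, says. Compound 1 and compound 3 give numbers that lie within the scatter of each other.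

Compound 3 is made from compound 2 by one change, (a group of 8 heavy atoms (7 carbon, 1 selenium; one six-membered aromatic ring of carbon only) in place of a group of 2 heavy atoms (1 carbon, 1 sulfur; no ring), on a carbon with a double bond to nitrogen). In this assay it produced an at least 1.1-fold lower number from compound 2 to compound 3 (0.05 log units; that floor lies within the scatter).

Compound 1 and compound 2 share the same shape around the carbon with a double bond to nitrogen but carry different cores; how the two cores differ is not broken down here.

Compound 4, `O=C(/N=C(/NC(=O)c1cc2ccccc2s1)[Se]Cc1ccccc1)c1cc2ccccc2s1`, is not yet measured. It arises from compound 1 by the same change, (a group of 8 heavy atoms (7 carbon, 1 selenium; one six-membered aromatic ring of carbon only) in place of a group of 2 heavy atoms (1 carbon, 1 sulfur; no ring), on a carbon with a double bond to nitrogen), made at the same place.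

From compound 1 to compound 4 a step of about a 1.3-fold lower number from compound 1 to compound 4 (0.10 log units; within the scatter) is expected in this assay, because the same change gave an at least 1.1-fold lower number from compound 2 to compound 3 (0.05 log units; that floor lies within the scatter), a step whose floor lies within the scatter. For compound 4 the estimated value in this assay is 70000 nM, expected to fall between 25000 nM and 150000 nM.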

Compound 4, concentration lethal to 50% of the cells: > 100000 nM
Compound 4: a limit, no number (the forecaster's own chance of this, stated with the estimate: 30%); middle value at least 1.4-fold (0.15 log units) from the limit.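

In this assay compound 4 gives > 100000 nM, which is a limit of the assay and not a number. Putting the selenium group with its six-membered aromatic ring in place of methylsulfanyl, on the carbon with a double bond to nitrogen, gives an at least 1.1-fold higher number from compound 1 to compound 4 (0.05 log units; that floor lies within the scatter), and set beside the earlier step the result stays undecided: the same change on two cores in this assay, an at least 1.1-fold lower number (0.05 log units; that floor lies within the scatter) from compound 2 to compound 3 and an at least 1.1-fold higher number (0.05 log units; that floor lies within the scatter) from compound 1 to compound 4; the limit leaves it open whether they differ The data therefore show neither that this change carries over from one core to the other with the same size nor that its size depends on the core, because limits stand in place of numbers for part of the series: the limit of > 100000 nM in this assay, at which 2 of the 4 values shown sit.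

The compounds shown leave open whether the selenium atom or the aromatic ring goes with any step on either core, a question that a methylselanyl group or a benzylsulfanyl group at the same place could address. They also leave open how either core would respond to an amine or a longer alkyl chain there.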